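The source may report more compounds than this note shows. Statements on the series, on what has been measured and on what is new or still open speak of the compounds shown alone.

Measured so far:
Compound 1 `CCC(c1ccccc1)c1cc(O)nc(SC2CCCCC2)n1`: 51000 nM
Compound 2 `CC(c1cc(O)nc(SC2CCCCC2)n1)c1c(Cl)cccc1Cl`: > 200000 nM

Both compounds were tested in a functional assay on MT4 cells (Homo sapiens) for cytotoxicity; on this read-out lower numbers stand for higher toxicity in this test and higher numbers for lower toxicity in this test. Compound 2 reads > 200000 nM, which is a limit of the assay and not a number.

Compound 3 `CCC(c1cc(O)nc(SC2CCCCC2)n1)c1c(Cl)cccc1Cl` has not yet been measured. It arises from compound 2 through a single change, methyl in place of hydrogen on a saturated chain carbon, two bonds along the chain from two aromatic carbons, so that methyl becomes ethyl.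

Going by the values given here, no two measured compounds differ in one place only, so no direct step is available as a guide. Compound 1 also carries the ethyl, and it gives 51000 nM in this assay, but it differs from compound 3 elsewhere as well. That value offers only weak support for a shift towards lower numbers, and the change may well stay within the scatter. A small step towards higher toxicity in this test is therefore expected, an at least 1.3-fold lower number from compound 2 to compound 3 (0.12 log units; that floor lies within the scatter). For compound 3 the estimated value is 150000 nM, with an expected range of 60000 nM to 300000 nM.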

Compound 3, half-maximal cytotoxic concentration: 200000 nM
Estimate against measurement, compound 3: 1.3-fold (0.12 log units) below, within the range that was stated.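

With the ethyl held in place, 2,6-dichlorophenyl in place of phenyl on the saturated chain carbon bound to an aromatic carbon and a saturated chain carbon gives a 3.9-fold higher number from compound 1 to compound 3 (0.59 log units; beyond the scatter) in this assay. Going by these compounds alone, this is the first step that can be read in size, and it runs towards lower toxicity in this test. Compound 2 gives only a limit of the assay and not a number: the limit of > 200000 nM in this assay, at which 1 of the 3 values shown sits.

That leaves the step for methyl in place of hydrogen unreadable in size: the change from methyl to ethyl gives a number no higher from compound 2 to compound 3 (the limit leaves the size open), and the data say nothing further about it. The compounds shown leave open whether a single chlorine on the phenyl would give part of the step seen with 2,6-dichlorophenyl, and whether a longer chain such as propyl on the same carbon would hold the number where compound 3 stands. Nor do they show what an amine on the phenyl in place of chlorine would do in this assay.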